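This account rests on a few compounds, and the source may have more. Where it says the series, first, only, none or still open, it means among the compounds named here.

Of the compounds shown here, three that share one core have so far been measured in an assay on Sf9 cells for inhibition of protein deacetylase HDAC6 (Homo sapiens), read by fluorescence, with a stated time of 40 min, tested at 100 nM; a lower number here means less inhibition, a higher number more inhibition at the concentration tested (going by the name of the read-out). Compound 1, `O=C(NO)c1ccc(NCc2nc(-c3ccc(Br)cc3)nn2-c2ccccc2)cc1`, gives 54.7% in this assay. Compound 2, `O=C(NO)c1ccc(NCc2nc(-c3cccnc3)nn2-c2ccccc2)cc1`, gives 57.7%. Compound 3, `COc1ccc(-n2nc(-c3ccc(O)cc3)nc2CNc2ccc(C(=O)NO)cc2)cc1`, gives 70.3%. Among these three numbers compound 2 stands second highest: the gap to compound 1, a number 3 percentage points higher from compound 1 to compound 2 (within the scatter), lies within the scatter, so the two cannot be told apart, while the number of compound 3 lies beyond the scatter from that of compound 2 and is the only one that clearly differs.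

The next compound, compound 4, is `O=C(NO)c1ccc(NCc2nc(-c3ccccc3)nn2-c2ccccc2)cc1`. It differs from compound 2 in one place: phenyl in place of pyridin-3-yl on an aromatic carbon. Among the measured compounds shown here, only one measured step bears on this change, namely the swap of one six-membered aromatic ring for another at the same place on the core, which gave a number 3 percentage points higher from compound 1 to compound 2 (within the scatter), a difference within the scatter. On that basis the step of a number 1.7 percentage points lower from compound 2 to compound 4 (within the scatter) is expected to stay within the scatter, with no direction to call. Compound 4 is therefore estimated to give about 56% in this assay, most likely falling somewhere from 44% to 68%.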

Compound 4, a percentage reported as inhibition, at one concentration (the size of the read-out at that concentration, not a potency): 72.6%
For compound 4 the middle estimate is 16.6 percentage points below the measured one; measured number outside the range, above it.
By their numbers in this assay, from the lowest: compounds 1 and 2 (each within the scatter of the next); then compounds 3 and 4 (each within the scatter of the next).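

In this assay the group on this aromatic carbon of the shared core now clearly matters: a number 14.9 percentage points higher from compound 2 to compound 4 (beyond the scatter) and a number 17.9 percentage points higher from compound 1 to compound 4 (beyond the scatter) both lie beyond the scatter, whereas the earlier swap at the same place, a number 3 percentage points higher from compound 1 to compound 2 (within the scatter) and so gave no readable difference. Plain phenyl therefore stands apart from both pyridin-3-yl and 4-bromophenyl, so that in these three compounds either a ring nitrogen in place of a ring carbon or a bromo on the phenyl ring goes with a lower number. What lies behind the gain, and behind two such different changes giving numbers that cannot be told apart, finds no support in any measurement given here.

Compound 3 also carries a different ring at this place, but it differs from compound 4 in more than one place, so that comparison cannot be read as a step. From the compounds shown here alone, it stays open whether the phenyl result would hold against other groups at this position, such as a small amine, a carboxylic acid or a longer alkyl chain, and whether other substituents on the phenyl ring would lower the number as bromo does.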